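The compounds below may be only part of what the source reports. "The series", "measured", "known", "first", "only" and "open" are said of these compounds alone.

Working notes on the pyrrolidine amide series. Three compounds have numbers in an assay on HEK293 cells for inhibition of N-acylethanolamine-hydrolyzing acid amidase (Rattus norvegicus), read by LC-MS, with a stated time of 30 min; a higher number here means a weaker inhibitor, a lower number a stronger inhibitor. Compound 1 `Cc1cccc(CCCCCCC(=O)N2CCCC2)c1` gives 8300 nM in this assay. Compound 2 `Cc1ccc(CCCCCCC(=O)N2CCCC2)cc1` gives 9600 nM in this assay, the highest of the three numbers; its gap to compound 1 lies within the scatter, so no order between these two is claimed. Compound 3 `O=C(CCc1ccc(-c2cccc(F)c2)cc1)N1CCCC1` gives 1800 nM in this assay, and the gap between compound 3 and compound 2 lies beyond the scatter. Within the data shown here, no two measured compounds differ in a single place, so no single step has been measured in this assay.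

Compound 4 `O=C(O)c1ccc(CCCCCCC(=O)N2CCCC2)cc1` is not yet measured. It differs from compound 2 in one place: carboxy in place of methyl on an aromatic carbon. Among the measured compounds shown here, none of the measured compounds carries a carboxy on the aromatic ring, so this step has no precedent and its size must be guessed. The step is expected to run toward a higher number, estimated as a 2.1-fold higher number from compound 2 to compound 4 (0.32 log units; beyond the scatter). Compound 4 is expected to give about 20000 nM in this assay, with a range from 6000 nM to 60000 nM. For the measured compounds named here, the range is set wide because compound 2 already gives 9600 nM, the highest of the measured numbers, and the step itself has no measured counterpart.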

Compound 4, half-maximal inhibitory concentration: > 100000 nM
Compound 4 ended at the assay's limit; the forecaster's own chance of this, stated with the estimate: 30%; middle value at least 5.0-fold (0.69 log units) away from the limit.
By their numbers in this assay, from the lowest: compound 3; then compounds 1 and 2 (each within the scatter of the next). At a limit, above all of these: compound 4.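

In this assay compound 4 gives > 100000 nM as a limit of the assay and not as a number: the limit of > 100000 nM in this assay, at which 1 of the 4 values shown sits.

Carboxy in place of methyl on an aromatic carbon, para to a large group, gives an at least 10-fold higher number from compound 2 to compound 4 (1.01 log units; beyond the scatter) and sets only a lower bound on the size of the change, with its full size unread. Compounds 1 and 2 both carry methyl and lie within the scatter of each other, so they gave no sign that a change of group on this ring could move the number this far.

This is a single pair, so it sets no pattern for the series, and the compounds shown leave open whether the carboxy in particular carries the loss or whether other groups at this place, such as a methyl ester, a primary amide or a hydroxy, would do the same. Also open, on these data alone, is whether a carboxylic acid on the core of compound 3 would cost as much there, and whether a longer chain between the ring and the carboxy would recover any of the loss.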